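Two Amide Side Chains and an Untested Acid

A few compounds are considered here, and "the series" means these few. Any claim that something is new, unique, unknown or untested is made for them only; others in the source may bear on it.

Measured in a functional assay on MCF7 cells (Homo sapiens) for antiproliferative activity, read by MTT assay, with a stated time of 24 h; on this read-out higher numbers stand for weaker inhibition and lower numbers for stronger inhibition:
- compound 1 `CCn1c(C(=O)NCCO)ccc1C(CC)(CC)c1ccc(OCS(=O)(=O)c2ccccc2)c(C)c1`: 15500 nM
- compound 2 `CCn1c(C(=O)N[C@@H](CO)CCCO)ccc1C(CC)(CC)c1ccc(OCS(=O)(=O)c2ccccc2)c(C)c1`: 29600 nM

For the measured compounds named here, compound 2, at 29600 nM, stands within the usual scatter of compound 1, at 15500 nM, so these two numbers set no order between the compounds. The next compound to be tested is compound 3 `CCn1c(C(=O)N[C@@H](C)C(=O)O)ccc1C(CC)(CC)c1ccc(OCS(=O)(=O)c2ccccc2)c(C)c1`. It keeps the shared core and exchanges the side group of compound 2: a group of 5 heavy atoms (3 carbon, 2 oxygen; no ring) in place of a group of 7 heavy atoms (5 carbon, 2 oxygen; no ring), on an amide-type nitrogen. The entering group is 1-carboxyethyl, and it sits on an amide-type nitrogen.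

Going by the values given here, only one measured step bears on this change: a 1.9-fold higher number from compound 1 to compound 2 (0.28 log units; within the scatter). That step altered the same side chain, adding 3-hydroxypropyl in place of hydrogen, and it stayed within the scatter. Among the compounds with values here, no measured compound carries 1-carboxyethyl, so this evidence is indirect and the range must stay wide. On that single step, no change beyond the scatter is expected in this assay, in either direction. The expected change is a 1.2-fold lower number from compound 2 to compound 3 (0.07 log units; within the scatter). For compound 3 the estimated value is 25000 nM, with an expected range of 10000 nM to 60000 nM.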

Compound 3, half-maximal inhibitory concentration: 35500 nM
Beside the measured number, compound 3's estimate is 1.4-fold (0.15 log units) below it, within the range that was stated.
By their numbers in this assay, from the lowest: compounds 1, 2 and 3 (each within the scatter of the next, the first and the last beyond it).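

With 1-carboxyethyl on the amide-type nitrogen, this assay shows a 1.2-fold higher number from compound 2 to compound 3 (0.08 log units; within the scatter), so this exchange sets no order between those two compounds, even though the entering group has a carboxylic acid in place of the two hydroxyl ends of the group that leaves. Set against 2-hydroxyethyl at the same place, the same entering group gives a 2.3-fold higher number from compound 1 to compound 3 (0.36 log units; beyond the scatter), a modest step and the first in this small set to pass beyond the scatter, which shows that a change of side chain on this nitrogen can shift the number measurably, here toward weaker inhibition. The data shown offer no explanation for this shift.

The compounds shown leave open whether the shift belongs to the carboxylic acid itself or to the carbon chain that carries it, a question that a methyl ester or a longer chain ending in the same acid would bear on. They also leave open how this position would respond to an amine on the side chain, or to the mirror-image form of the 1-carboxyethyl group.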